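Second fluoro on the aryl group of compound 2

The source may hold more compounds than are shown below. What is called first, only, known or untested is meant among the compounds shown, and "the series" means these compounds.

The series shares the core seen in compound 1 `Nc1scc(CN2CCN(c3cccc4ccccc34)CC2)c1C(=O)c1ccc(Cl)cc1`, which carries a naphthalen-1-yl on the ring amine nitrogen. Compound 2 `Nc1scc(CN2CCN(c3cccc(F)c3)CC2)c1C(=O)c1ccc(Cl)cc1` has a 3-fluorophenyl in its place. In a functional assay on CHO cells with adenosine receptor A1 (Homo sapiens) as the target, read by cAMP accumulation and immunoassay, with a stated time of 6 min, tested at 0.1 uM (on this read-out lower numbers stand for a stronger effect and higher numbers for a weaker effect at the one concentration tested), compound 1 gives 0% and compound 2 gives -37%. Within the data shown here, compound 2 therefore stands at the lowest of the two numbers, and the single measured step, a number 37 percentage points lower from compound 1 to compound 2 (beyond the scatter), separates it from compound 1 by more than the scatter.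

Compound 3 `Nc1scc(CN2CCN(c3cc(F)ccc3F)CC2)c1C(=O)c1ccc(Cl)cc1` is not yet measured. It differs from compound 2 by fluoro in place of hydrogen on an aromatic carbon. Among the measured compounds shown here, the one measured step, a number 37 percentage points lower from compound 1 to compound 2 (beyond the scatter), exchanges the whole aryl group and so says nothing about adding a fluoro to a ring that already carries one; no measured pair in this set bears on that change. For the measured compounds named here, with no step to lean on, the expected step of a number 7 percentage points higher from compound 2 to compound 3 (within the scatter) lies within the scatter. For compound 3 the estimate in this assay is -30%, within a range from -60% to 0%.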

Compound 3, a percentage reported as activity, at one concentration (the size of the read-out at that concentration, not a potency): -13%
Compound 3: the middle estimate sits 17 percentage points below what was measured; low and high end bracket the measured number.
By their numbers in this assay, from the lowest: compound 2; then compound 3; then compound 1.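

In this assay, the carbon ortho to a large group and para to a fluoro group is sensitive to substitution: going from 3-fluorophenyl to 2,5-difluorophenyl, fluoro in place of hydrogen gives a number 24 percentage points higher from compound 2 to compound 3 (beyond the scatter). The opening comparison exchanged the whole aryl group, whereas this single added fluoro moves the read-out towards a weaker effect at the one concentration tested, and the 2,5-difluorophenyl group remains separated from the naphthalen-1-yl group by a number 13 percentage points lower from compound 1 to compound 3 (beyond the scatter). The order of the three numbers therefore places compound 3 between compound 2 and compound 1, but no supporting measurement accounts for the shift.

Still open, going by these compounds, is whether this upward move belongs to fluoro itself or would also appear with another group on the same aromatic carbon, such as chloro, methyl or methoxy. The compounds shown also leave open whether the same change would give a similar step with the 4-chlorobenzoyl part of the shared core replaced, and how these single-concentration numbers relate to potency.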